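The source may report more compounds than this note shows. Statements on the series, on what has been measured and on what is new or still open speak of the compounds shown alone.

Working notes on the series. In an ADME assay on GES1 cells (Homo sapiens) for inhibition, read by MTT assay, with a stated time of 72 h (on this read-out lower numbers stand for stronger inhibition and higher numbers for weaker inhibition), compound 1 `Cc1cc(Nc2ccn(Cc3ccccc3)n2)n2nc(SCc3ccc(Br)cc3)nc2n1` gives 44400 nM, compound 3 `Cc1cc(Nc2ccn(Cc3ccc(F)cc3)n2)n2nc(SCc3ccc(Br)cc3)nc2n1` gives 40500 nM, and compound 2 `Cc1cc(Nc2cc(-c3ccccc3)[nH]n2)n2nc(SCC(=O)c3ccccc3)nc2n1` gives 33300 nM; compound 2 lies within the scatter of both compound 3 and compound 1, so the three cannot be told apart on this assay. Compound 4 `COc1ccc(CSc2nc3nc(C)cc(Nc4cc(-c5ccccc5)[nH]n4)n3n2)cc1` carries 4-methoxyphenyl in place of benzoyl on a saturated chain carbon bound to a sulfur. Among the measured compounds shown here, the only step measured so far, a 1.1-fold lower number from compound 1 to compound 3 (0.04 log units; within the scatter), concerns a different change and stays within the scatter; no measured step touches the group bound to the sulfur. With nothing in the data that moves the numbers, the step from compound 2 to compound 4 in this assay is expected to be a 1.0-fold lower number from compound 2 to compound 4 (0.00 log units; within the scatter), none beyond the scatter. Compound 4 is therefore estimated at 33000 nM, between 15000 nM and 75000 nM.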

Compound 4, half-maximal inhibitory concentration: 28200 nM
The estimate for compound 4 lay 1.2-fold (0.07 log units) above the measured number, and the stated range covers the measured number.
By their numbers in this assay, from the lowest: compounds 4, 2, 3 and 1 (each within the scatter of the next).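

In this assay, the first step read at the group bound to the sulfur, a 1.2-fold lower number from compound 2 to compound 4 (0.07 log units; within the scatter), stays within the scatter. On a saturated chain carbon bound to a sulfur, 4-methoxyphenyl in place of benzoyl gives up the double bond outside aromatic rings at an unchanged heavy-atom count, and the read-out does not separate the two compounds. No measured evidence bears on this result. Still open, going by these compounds, is whether an amine or a carboxylic acid at this place would give a step beyond the scatter. On these data alone, a longer chain bound to the sulfur remains equally open.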